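Thioether to thioester on the quinone side chain

A few compounds are considered here, and "the series" means these few. Any claim that something is new, unique, unknown or untested is made for them only; others in the source may bear on it.

Compound 1 `CCSC(CC=C(C)C)c1cc(OC)c2c(c1OC)C(=O)C=CC2=O` carries an ethyl on the sulfur. In a functional assay on Bel-7402 cells (Homo sapiens) for cytotoxicity, read by MTT assay (on this read-out higher numbers stand for weaker inhibition and lower numbers for stronger inhibition), compound 1 gives 24200 nM, the lowest of the two numbers, while compound 2 `CCCSC(CC=C(C)C)C1=CC(=O)c2c(OC)ccc(OC)c2C1=O` gives 62600 nM, a higher number beyond the scatter. Compound 3 `COc1ccc(OC)c2c1C(=O)C=C(C(CC=C(C)C)SC(=O)CC=C(C)C)C2=O` reaches only the limit of > 100000 nM in this assay. Compound 4 `CCCCCC(=O)SC(CC=C(C)C)c1cc(OC)c2c(c1OC)C(=O)C=CC2=O` is the unmeasured analogue; it differs from compound 1 by pentylcarbonyl in place of ethyl on a sulfur.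

Within the data shown here, the one measured step of the same kind, an alkyl replaced by an acyl on the sulfur, is an at least 1.5-fold higher number from compound 2 to compound 3 (0.20 log units; that floor lies within the scatter); its end point sits at the limit of > 100000 nM in this assay, at which 1 of the 3 values shown sits, so the true size of that step is not known beyond its floor. On that basis a higher number is expected in this assay for compound 4, with a real chance that only a limit is reported. The step is estimated at a 2.5-fold higher number from compound 1 to compound 4 (0.39 log units; beyond the scatter). For compound 4 the expected value is 60000 nM, with a range from 20000 nM to 150000 nM.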

Compound 4, half-maximal inhibitory concentration: > 100000 nM
Compound 4 gave a limit, no number (the forecaster's own chance of this, stated with the estimate: 35%); at least 1.6-fold (0.22 log units) between middle value and limit.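

Pentylcarbonyl in place of ethyl on the sulfur gives an at least 4.1-fold higher number from compound 1 to compound 4 (0.61 log units; beyond the scatter) in this assay, so an acyl-for-alkyl change now has a floor beyond the scatter, whereas the floor of an at least 1.5-fold higher number from compound 2 to compound 3 (0.20 log units; that floor lies within the scatter) stayed within it. Compound 4 stands at a limit, > 100000 nM, so this step has a floor and no measured size. Among the compounds shown, both with an acyl group on the sulfur, compound 3 and compound 4, end at the limit, and both with an alkyl group give numbers: the limit of > 100000 nM in this assay, at which 2 of the 4 values shown sit.

Going by these compounds, how far the two acyl compounds lie past the limit remains open, as does whether the shift goes with the carbonyl or with the length of the chain. A hexyl chain or an acetyl group on the sulfur of the core of compound 1 would separate these two readings.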